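This account rests on a few compounds, and the source may have more. Where it says the series, first, only, none or still open, it means among the compounds named here.

Working notes on the series. In a functional assay on HT-29 cells (Homo sapiens) for cytotoxicity, read by resazurin assay, with a stated time of 48 h (on this read-out higher numbers stand for an effect only at larger amounts of compound and lower numbers for an effect already at smaller amounts), compound 1 (`O=C(Nc1ccc(Sc2nc3ccccc3s2)c(Cl)c1)c1cccc(Br)c1O`) gives 20000 nM and compound 3 (`O=S(=O)(Nc1ccc(-c2nc3cc(NS(=O)(=O)c4ccc(Cl)s4)ccc3o2)cc1)c1ccc(Cl)s1`) gives 33000 nM, two values within the scatter of each other. Compound 2 (`O=C(Nc1ccc(Sc2nc3ccccc3s2)cc1)c1cccc(Br)c1O`) gives 9300 nM, which puts compound 1 towards the upper end of this small set.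

Compound 4 (`COc1c(Br)cccc1C(=O)Nc1ccc(Sc2nc3ccccc3s2)c(Cl)c1`) has not yet been measured. It differs from compound 1 as follows: methyl in place of hydrogen on an oxygen on an aromatic ring, or hydroxy to methoxy.

For the measured compounds named here, no measured step covers this change. Going by the values given here, the only step available, a 2.2-fold lower number from compound 1 to compound 2 (0.33 log units; beyond the scatter), is modest and concerns hydrogen in place of chloro on an aromatic carbon, so it bears on the new change only indirectly. With so little to go on, no shift beyond the scatter is expected in this assay, and no direction is favoured with any confidence.

The expected step is a 1.3-fold higher number from compound 1 to compound 4 (0.10 log units; within the scatter). For compound 4 the estimated value is 25000 nM, with an expected range of 10000 nM to 60000 nM.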

Compound 4, half-maximal effective concentration: 11000 nM
Compound 4: the middle estimate sits 2.3-fold (0.36 log units) above what was measured, within the range that was stated.
By their numbers in this assay, from the lowest: compounds 2, 4, 1 and 3 (each within the scatter of the next, the first and the last beyond it).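

In this assay the change from hydroxy to methoxy gives a 1.8-fold lower number from compound 1 to compound 4 (0.26 log units; within the scatter) and so does not separate the two compounds. For the compounds shown here, this is the first reading at this oxygen on an aromatic ring, and in this single pair, methyl in place of hydrogen leaves the number within the scatter, so the hydrogen on this oxygen is not needed for an effect in this range. No measurement shown accounts for this result or links it to any property of the group.

Open, from the compounds shown here alone, is whether an ethyl group or a longer chain on this oxygen, or an amine in place of the hydroxy, would also stay within the scatter. Also open, going by these compounds, is whether the same change would read alike on compound 2, which has hydrogen in place of chloro.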